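Swapping a Side Group on a Nucleoside Core

The compounds below may be only part of what the source reports. "The series", "measured", "known", "first", "only" and "open" are said of these compounds alone.

Of the compounds shown here, three have been tested in an ADME assay on L1210/0 cells (Mus musculus) for cytotoxicity, with a stated time of 48 h; on this read-out higher numbers stand for weaker inhibition and lower numbers for stronger inhibition. Compound 1 `CO[C@@H]1OC[C@@H](OC(C)=O)[C@@H](OC(C)=O)[C@]1(F)n1ccc(=O)[nH]c1=O` gives 55000 nM. Compound 2 `Cc1ccc(C(=O)/C=C/c2cc(O)nc(O)n2)cc1` gives 182000 nM. Compound 3 `[N-]=[N+]=NCc1cn([C@H]2C[C@H](O)[C@@H](CO)O2)c(=O)[nH]c1=O` gives 124000 nM. Among these three numbers compound 3 holds the second highest; its nearest neighbour is compound 2, whose number lies within the usual scatter of compound 3, so no order can be read between those two. Compound 1 sits further off, with a number lower than that of compound 3 by more than the scatter, which points to stronger inhibition for compound 1.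

The next compound, compound 4 `CC#Cc1cn([C@H]2C[C@H](O)[C@@H](CO)O2)c(=O)[nH]c1=O`, differs from compound 3 in one place: prop-1-yn-1-yl in place of azidomethyl on an aromatic carbon. Among the measured compounds shown here, no pair among the measured compounds shares this change, so its size has not been observed here. Since the rest of compound 3 is kept, a step of modest size toward a lower number is expected, a 4.1-fold lower number from compound 3 to compound 4 (0.62 log units; beyond the scatter). Compound 4 is therefore expected to give about 30000 nM, within a range from 5000 nM to 150000 nM.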

Compound 4, half-maximal inhibitory concentration: > 200000 nM
Compound 4 ended at the assay's limit; the forecaster's own chance of this, stated with the estimate: 10%; middle value at least 6.6-fold (0.82 log units) away from the limit.
By their numbers in this assay, from the lowest: compound 1; then compounds 3 and 2 (each within the scatter of the next). At a limit, above all of these: compound 4.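

In this assay compound 4 gives > 200000 nM as a limit of the assay and not as a number. Among the compounds shown here, the step of an at least 1.6-fold higher number from compound 3 to compound 4 (0.20 log units; that floor lies within the scatter) is the first look at this position on the shared core, and it is only a floor, so the true size of the change stays unknown. What it does show is that prop-1-yn-1-yl in place of azidomethyl on this aromatic carbon brought no stronger inhibition, and no sign of a lower number appears with this swap.

As far as these compounds go, whether an amine, a carboxylic acid or a longer chain at the same aromatic carbon would move the number in either direction remains open. So does whether this swap would behave the same way on a different core.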